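Moving the Methyl on the Amide Aryl Group

A few compounds are considered here, and "the series" means these few. Any claim that something is new, unique, unknown or untested is made for them only; others in the source may bear on it.

Compound 1, `Cc1c(C(=O)N(CC(=O)O)c2ccc(C(F)(F)F)cc2)cnn1-c1ccc(F)cc1`, in a functional assay with Homo sapiens as the target; on this read-out higher numbers stand for weaker inhibition and lower numbers for stronger inhibition: 3200 nM
Compound 2, `Cc1ccc(NC(=O)c2cnn(-c3ccc(F)cc3)c2C)cc1`, in this assay: 540 nM

Compound 2 gives the lowest of the two numbers; compound 1 lies above it by a gap well beyond the usual scatter. Compound 3, `Cc1ccccc1NC(=O)c1cnn(-c2ccc(F)cc2)c1C`, differs from compound 2 by 2-methylphenyl in place of 4-methylphenyl on an amide-type nitrogen. Going by the values given here, no measured pair shows this kind of change, so in this assay only a modest step is expected, possibly toward weaker inhibition, or none beyond the scatter. Compound 3 is therefore expected to give about 1000 nM, within a range of 300 nM to 4000 nM. This corresponds to an expected step of a 1.9-fold higher number from compound 2 to compound 3 (0.27 log units; within the scatter).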

Compound 3, half-maximal inhibitory concentration: 1100 nM
Compound 3: the middle estimate sits 1.1-fold (0.04 log units) below what was measured; the measured number falls inside the stated range.
By their numbers in this assay, from the lowest: compound 2; then compound 3; then compound 1.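

Moving the methyl, with the same atoms joined differently, still shifts the read-out in this assay: 2-methylphenyl in place of 4-methylphenyl on the amide-type nitrogen gives a 2.0-fold higher number from compound 2 to compound 3 (0.31 log units; beyond the scatter) and so a modest loss of inhibition. This position therefore responds to where the methyl sits and not only to which atoms are present, although the step only just clears the scatter. Nothing available explains this shift. Still open, on these data alone, is whether a methoxy group or an amine in place of that methyl would give a lower number or a higher one.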